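A few compounds are considered here, and "the series" means these few. Any claim that something is new, unique, unknown or untested is made for them only; others in the source may bear on it.

Measured in a functional assay on K562 cells (Homo sapiens) for cytotoxicity, read by ELISA, with a stated time of 4 days; on this read-out higher numbers stand for weaker inhibition and lower numbers for stronger inhibition:
compound 1 `Cc1ccsc1-c1cc(-c2ccco2)cc(-c2ccccc2Cl)n1`: 25400 nM
compound 2 `Cc1ccsc1-c1cc(-c2ccco2)cc(-c2ccc(Cl)cc2)n1`: 20700 nM
compound 3 `Cc1ccsc1-c1cc(-c2ccoc2)cc(-c2ccc(Cl)cc2)n1`: 19600 nM

Compound 2, at 20700 nM, cannot be told apart from the other two compounds, as the steps on either side of it show: a 1.2-fold lower number from compound 1 to compound 2 (0.09 log units; within the scatter), and a 1.1-fold lower number from compound 2 to compound 3 (0.02 log units; within the scatter).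

Compound 4 `Clc1ccc(-c2cc(-c3ccco3)cc(-c3ccc(Cl)s3)n2)cc1` keeps the 4-chlorophenyl and furan-2-yl groups of compound 2 and changes one other group. It carries 5-chlorothiophen-2-yl in place of 3-methylthiophen-2-yl, on an aromatic carbon next to the ring nitrogen (5-chlorothiophen-2-yl in place of 3-methylthiophen-2-yl on an aromatic carbon).

Both measured steps bear on this only indirectly, since they swap other groups, the chlorophenyl in the first and the furan in the second. As far as these compounds go, all three measured compounds carry the same 3-methylthiophen-2-yl group, so this place is untested. With no measured guide to a direction, no step beyond the scatter is expected, and the range must stay wide. The estimated step is a 1.2-fold lower number from compound 2 to compound 4 (0.06 log units; within the scatter). For compound 4 the expected value is 18000 nM, with an estimated range of 7000 nM to 40000 nM.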

Compound 4, half-maximal inhibitory concentration: 10500 nM
Compound 4: the middle estimate sits 1.7-fold (0.23 log units) above what was measured, and the stated range covers the measured number.
By their numbers in this assay, from the lowest: compounds 4, 3, 2 and 1 (each within the scatter of the next, the first and the last beyond it).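

Compound 4 is the only compound shown that varies the group on the aromatic carbon next to the ring nitrogen, and in this assay 5-chlorothiophen-2-yl in place of 3-methylthiophen-2-yl gives a 2.0-fold lower number from compound 2 to compound 4 (0.29 log units; within the scatter). The two compounds therefore cannot be told apart, so this place can hold either thiophene, one with a methyl group and the other with a chlorine, with no difference beyond the usual scatter of the measurement. No measured information bears on why the number falls where it does.

The compounds shown leave open whether a group other than a thiophene at this place, such as an amine or a carboxylic acid, would move the number beyond the scatter. They also leave open whether the 5-chlorothiophen-2-yl group would behave the same way alongside furan-3-yl or 2-chlorophenyl.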